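The source may report more compounds than this note shows. Statements on the series, on what has been measured and on what is new or still open speak of the compounds shown alone.

Values in an ADME assay on MT4 cells (Homo sapiens) for cytotoxicity; on this read-out higher numbers stand for lower toxicity in this test and lower numbers for higher toxicity in this test:
- compound 1 `Cc1cc(C)cc(S(=O)(=O)n2c(SCC(=O)Nc3ccccc3[N+](=O)[O-])nc3ccc(Cl)cc32)c1`: > 235000 nM (a limit)
- compound 2 `Cc1cc(C)cc(S(=O)(=O)n2c(SCC(=O)Nc3ccc(C)cc3Cl)nc3ccc(Cl)cc32)c1`: > 234000 nM (a limit)
- compound 3 `COC(=O)c1ccc(NC(=O)CSc2nc3ccccc3n2S(=O)(=O)c2cc(C)cc(C)c2)c(Cl)c1`: 145000 nM

Among the measured compounds shown here, compound 3 holds the only actual number here, as the other two values are limits. Compound 4 `COC(=O)c1ccc(NC(=O)CSc2nc3ccc(Cl)cc3n2S(=O)(=O)c2cc(C)cc(C)c2)c(Cl)c1` carries chloro in place of hydrogen on an aromatic carbon of the core, (chloro in place of hydrogen on an aromatic carbon). For the measured compounds named here, the one measured step, a step that the two limits leave unreadable from compound 1 to compound 2, concerns the amide-type nitrogen substituent and gives no size. Going by the values given here, no measured pair isolates this chloro. Compound 1 carries it and gives only a limit, > 235000 nM. Compound 2 also carries it and gives only a limit, > 234000 nM. On that weak basis, the expected step, a 1.2-fold higher number from compound 3 to compound 4 (0.09 log units; within the scatter), points upward. The estimated value for compound 4 is 180000 nM, with an expected range of 90000 nM to 260000 nM.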

Compound 4, half-maximal cytotoxic concentration: >= 130000 nM
Compound 4 ended at the assay's limit (the forecaster's own chance of this, stated with the estimate: 50%); the middle value is on the limit's open side.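

The value of compound 4 is a limit, and its steps from compound 1, compound 2 and compound 3 cannot be read. From the compounds shown here alone, whether chloro in place of hydrogen on an aromatic carbon shifts cytotoxicity stays open.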